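Chloro to nitro swap at a second place: tolerability notes

The source may hold more compounds than are shown below. What is called first, only, known or untested is meant among the compounds shown, and "the series" means these compounds.

Compound 1 `O=C(COc1cccc2ccccc12)N/N=C/c1ccc(Cl)cc1` is the reference point of the set; in an ADME assay on MT4 cells (Homo sapiens) for cytotoxicity, read by MTT assay, with a stated time of 4 days (a lower number here means that less compound is tolerated, a higher number that more compound is tolerated), compound 1 gives 87.6 ug/mL. Compound 2 `O=C(COc1cccc2ccccc12)N/N=C/c1ccc([N+](=O)[O-])cc1` carries the change nitro in place of chloro on an aromatic carbon and gives 87.9 ug/mL in this assay, so the step of a 1.0-fold higher number from compound 1 to compound 2 (0.00 log units; within the scatter) is flat. Compound 3 `O=C(COc1cccc2ccccc12)N/N=C/c1ccccc1Cl` differs from compound 1 in its core by 2-chlorophenyl in place of 4-chlorophenyl on a carbon with a double bond to nitrogen. In this assay compound 3 gives 56.2 ug/mL; the step of a 1.6-fold lower number from compound 1 to compound 3 (0.19 log units; within the scatter) stays within the scatter. Going by the values given here, compound 3 and compound 2 have no step counted between them; their two values alone sit close together.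

Compound 4 `O=C(COc1cccc2ccccc12)N/N=C/c1ccccc1[N+](=O)[O-]` is not yet measured. It differs from compound 3 by nitro in place of chloro on an aromatic carbon. This is the same kind of change as from compound 1 to compound 2, but not the same: there the place was para to a large group, here it is ortho to a large group. The expectation for the step from compound 3 to compound 4 in this assay is a 1.0-fold higher number from compound 3 to compound 4 (0.01 log units; within the scatter), close to flat, because the earlier step of a 1.0-fold higher number from compound 1 to compound 2 (0.00 log units; within the scatter) showed no movement. Compound 4 is therefore estimated at 58 ug/mL, with a likely range from 35 ug/mL to 100 ug/mL.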

Compound 4, half-maximal cytotoxic concentration: 12.2 ug/mL
The estimate for compound 4 lay 4.8-fold (0.68 log units) above the measured number, and the stated range ends above it.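

Nitro in place of chloro does not carry from one core to the other as a fixed step. In this assay the change on the core of compound 3 gives a 4.6-fold lower number from compound 3 to compound 4 (0.66 log units; beyond the scatter), and it differs from the same change on the core of compound 1: the same change on two cores in this assay, a 1.0-fold higher number (0.00 log units; within the scatter) from compound 1 to compound 2 and a 4.6-fold lower number (0.66 log units; beyond the scatter) from compound 3 to compound 4, 4.6-fold (0.66 log units) apart, beyond the scatter of two such steps. So the effect of this swap depends on its setting: a group ortho to a large group need not follow what was seen on the core of compound 1. Going by these compounds alone, this rests on only two pairs, however, and it does not show what lies behind the gap, nor that every change made ortho to a large group would diverge in the same way.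

Going by these compounds, it remains open whether an amine or a carboxylic acid ortho to a large group would stay close to compound 3 or fall toward compound 4. Also open, on these data alone, is whether a methoxy group or a longer chain there would give a step of either size.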